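A few compounds are considered here, and "the series" means these few. Any claim that something is new, unique, unknown or untested is made for them only; others in the source may bear on it.

In a functional assay on A549 cells (Homo sapiens) for antiproliferative activity, read by MTT assay, with a stated time of 48 h (on this read-out higher numbers stand for weaker inhibition and lower numbers for stronger inhibition), compound 2 `O=c1cc(-n2cc(COc3ccccc3)nn2)c2cc(Br)ccc2o1` gives 12300 nM, compound 1 `O=c1cc(-n2cc(CSc3ccccc3)nn2)c2cc(Br)ccc2o1` gives 3510 nM and compound 3 `O=c1cc(-n2cc(COc3cccnc3)nn2)c2cc(Br)ccc2o1` gives 24800 nM. Compound 2 thus stands within the scatter of compound 3, as a 2.0-fold higher number from compound 2 to compound 3 (0.30 log units; within the scatter) shows, and clear of compound 1, as a 3.5-fold higher number from compound 1 to compound 2 (0.54 log units; beyond the scatter) shows. Compound 4 `O=c1cc(-n2cc(COc3ccc(C(F)(F)F)cc3)nn2)c2cc(Br)ccc2o1` differs from compound 2 by trifluoromethyl in place of hydrogen on an aromatic carbon, para to a large group. Going by the values given here, no measured step makes this change. The nearest guides are the modest 3.5-fold higher number from compound 1 to compound 2 (0.54 log units; beyond the scatter) and a 7.1-fold higher number from compound 1 to compound 3 (0.85 log units; beyond the scatter), and the ring swap a 2.0-fold higher number from compound 2 to compound 3 (0.30 log units; within the scatter), which stays within the scatter. No clear direction follows from these, so the expected step in this assay is small. The estimated step is a 1.3-fold lower number from compound 2 to compound 4 (0.11 log units; within the scatter). For compound 4 the estimated value is 9500 nM, with an expected range of 3500 nM to 26000 nM.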

Compound 4, half-maximal inhibitory concentration: 1620 nM
Beside the measured number, compound 4's estimate is 5.9-fold (0.77 log units) above it; measured number below the stated range.
By their numbers in this assay, from the lowest: compound 4; then compound 1; then compounds 2 and 3 (each within the scatter of the next).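

In this assay, trifluoromethyl in place of hydrogen on an aromatic carbon, para to a large group, gives a 7.6-fold lower number from compound 2 to compound 4 (0.88 log units; beyond the scatter), which is stronger inhibition and beyond the scatter. Going by these compounds alone, the earlier steps changed only the linking atom or the ring type, so this is the first sign that a substituent on this ring carbon can shift the read-out. Nothing available accounts for the size of this step.

Going by these compounds, whether a chlorine, methoxy or amine group on the same carbon would give a similar shift remains open. Also open, on these data alone, is whether trifluoromethyl has the same effect on compound 1 or compound 3.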